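The source may hold more compounds than are shown below. What is called first, only, known or untested is meant among the compounds shown, and "the series" means these compounds.

Measured compounds:
Compound 1 `CCc1ccccc1N(CC(=O)NCc1ccc(OC)c(OC)c1)S(=O)(=O)c1ccc(C)cc1` gives 25.1 nM in an assay on CHO cells for displacement of a labelled ligand from prostaglandin E2 receptor EP1 subtype (Homo sapiens); on this read-out higher numbers stand for weaker inhibition and lower numbers for stronger inhibition.
Compound 2 `Cc1ccc(S(=O)(=O)N(CC(=O)NCc2ccc(Cl)cc2)c2cccnc2)cc1` gives < 1000 nM in this assay, which is a limit of the assay and not a number.

Among the compounds with values here, compound 2 therefore stands only at the limit of < 1000 nM in this assay, at which 1 of the 2 values shown sits, without a value of its own, and compound 1 is the single compound with a measured number. Compound 3 `Cc1ccc(S(=O)(=O)N(CC(=O)NCc2ccc(Cl)cc2)c2ccc(C)cn2)cc1` differs from compound 2 by 5-methylpyridin-2-yl in place of pyridin-3-yl on a sulfonamide nitrogen. Within the data shown here, no measured pair shows this change, so the step is expected to stay within the scatter, with no clear direction. Compound 3 is expected at 300 nM, between 50 nM and 3000 nM. That amounts to an expected step that the limit leaves unreadable from compound 2 to compound 3.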

Compound 3, inhibition constant: < 1000 nM
Compound 3 was reported as a limit (the forecaster's own chance of this, stated with the estimate: 40%); the middle value is on the limit's open side.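

Compound 2 and compound 3 are both reported only as limits in this assay, so no step between them can be read: the limit of < 1000 nM in this assay, at which 2 of the 3 values shown sit.

From the compounds shown here alone, what 5-methylpyridin-2-yl in place of pyridin-3-yl on a sulfonamide nitrogen does to the inhibition constant remains open.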